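Three Measured Compounds and an Expected Fourth

The source may hold more compounds than are shown below. What is called first, only, known or untested is meant among the compounds shown, and "the series" means these compounds.

Compound 1 `Cc1ccc(S(=O)(=O)/C(=C/c2ccc(Cl)cc2)C(=O)c2ccc(Cl)cc2)cc1` gives 1000 nM in a functional assay on DU-145 cells (Homo sapiens) for inhibition, read by trypan blue exclusion, with a stated time of 96 h; a lower number here means a stronger inhibitor of growth, a higher number a weaker inhibitor of growth.
Compound 2 `Cc1ccc(S(=O)(=O)/C(=C/c2cc(C)ccc2C)C(=O)c2ccc(Cl)cc2)cc1` gives 1000 nM in this assay.
Compound 3 `Cc1ccc(CS(=O)(=O)/C(=C/c2cc(C)ccc2C)C(=O)c2ccc(Cl)cc2)cc1` gives 1000 nM in this assay.

The three measured compounds sit level in this assay. Going from compound 2 to compound 1, the change is 4-chlorophenyl in place of 2,5-dimethylphenyl on a double-bonded chain carbon bound to a double-bonded chain carbon, and the step is no change at the digits printed from compound 2 to compound 1 (within the scatter). The two cores differ as 4-methylbenzyl in place of 4-methylphenyl on a sulfonyl sulfur, and that step is no change at the digits printed from compound 2 to compound 3 (within the scatter). Compound 3 thus stands within the scatter of both compound 1 and compound 2, so no order among the three can be read from these values.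

Compound 4 `Cc1ccc(CS(=O)(=O)/C(=C/c2ccc(Cl)cc2)C(=O)c2ccc(Cl)cc2)cc1` has not been measured. It differs from compound 3 by 4-chlorophenyl in place of 2,5-dimethylphenyl on a double-bonded chain carbon bound to a double-bonded chain carbon. This is the same change as that from compound 2 to compound 1, made at the same place, and it occurs twice among the compounds here. Because the measured instance gave no change at the digits printed from compound 2 to compound 1 (within the scatter), the step from compound 3 to compound 4 is expected to be no change at the digits printed from compound 3 to compound 4 (within the scatter) in this assay. Compound 4 is therefore estimated at 1000 nM, with a likely range from 500 nM to 2000 nM.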

Compound 4, concentration for 50% growth inhibition: 25000 nM
Beside the measured number, compound 4's estimate is 25-fold (1.40 log units) below it; the measured number lies above the stated range.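

With 4-methylbenzyl on the sulfonyl sulfur, 4-chlorophenyl in place of 2,5-dimethylphenyl gives a 25-fold higher number from compound 3 to compound 4 (1.40 log units; beyond the scatter) in this assay, so this change does not carry over from the core with 4-methylphenyl on that sulfur: the same change on two cores in this assay, no change at the digits printed (within the scatter) from compound 2 to compound 1 and a 25-fold higher number (1.40 log units; beyond the scatter) from compound 3 to compound 4, 25-fold (1.40 log units) apart, beyond the scatter of two such steps

Read the other way, 4-methylbenzyl in place of 4-methylphenyl on a sulfonyl sulfur gives a 25-fold higher number from compound 1 to compound 4 (1.40 log units; beyond the scatter), and this change also depends on the core: the same change on two cores in this assay, no change at the digits printed (within the scatter) from compound 2 to compound 3 and a 25-fold higher number (1.40 log units; beyond the scatter) from compound 1 to compound 4, 25-fold (1.40 log units) apart, beyond the scatter of two such steps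

Among these four compounds, the two changes do not act independently, but the result rests on compound 4 alone, so it shows that the steps differ without showing why or giving a rule for other cores.

On these data alone, it remains open whether the higher number for compound 4 is specific to 4-chlorophenyl or would also appear with a group such as 4-fluorophenyl or 4-methoxyphenyl on the core of compound 3. As far as these compounds go, it is equally open how 4-chlorophenyl would behave with a phenethyl chain or a benzyl group carrying an amine on the sulfonyl sulfur.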